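A Larger Sulfur-Bearing Group on a Thiosemicarbazone Core

The source may report more compounds than this note shows. Statements on the series, on what has been measured and on what is new or still open speak of the compounds shown alone.

Compound 1, `Cc1ccc(NC2=C/C(=N/NC(N)=S)C(=O)N=C2Nc2ccc(C)cc2)cc1`: 7040 nM
Compound 2, `NC(=S)N/N=C1/C=C(Nc2ccc(Br)cc2)C(Nc2ccc(Br)cc2)=NC1=O`: 2150 nM

In a functional assay on HCT-116 cells (Homo sapiens) for antiproliferative activity, read by MTT assay, with a stated time of 72 h (a lower number here means a stronger inhibitor, a higher number a weaker inhibitor), compound 1 gives 7040 nM, the highest of the two numbers, and so it is the weaker of the two. Compound 2 gives 2150 nM, a lower number whose gap to compound 1 lies beyond the usual scatter. Going by the values given here, no pair of compounds differing only in the part changed here has been measured, so the size and direction of this change are not known from data.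

Compound 3, `Cc1ccc(NC2=C/C(=N/N=C(\N)SCc3ccccc3)C(=O)N=C2Nc2ccc(C)cc2)cc1`, differs from compound 1 in one place: a group of 11 heavy atoms (8 carbon, 2 nitrogen, 1 sulfur; one six-membered aromatic ring of carbon only) in place of a group of 4 heavy atoms (1 carbon, 2 nitrogen, 1 sulfur; no ring), on a double-bonded nitrogen. The step from compound 1 to compound 3 is expected to be a 1.6-fold lower number from compound 1 to compound 3 (0.19 log units; within the scatter), a small move toward a lower number, hardly larger than the scatter itself. Compound 3 is therefore estimated at 4500 nM, with a range from 1200 nM to 15000 nM.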

Compound 3, half-maximal inhibitory concentration: 8270 nM
Compound 3: the middle estimate sits 1.8-fold (0.26 log units) below what was measured; measured number inside the range.
By their numbers in this assay, from the lowest: compound 2; then compounds 1 and 3 (each within the scatter of the next).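

Going by these compounds alone, compound 1 and compound 3 show the first measured step at this position, on a double-bonded nitrogen. In this assay, exchanging the group of 4 heavy atoms for the group of 11 heavy atoms, with its six-membered aromatic ring of carbon only, gives a 1.2-fold higher number from compound 1 to compound 3 (0.07 log units; within the scatter) and so leaves the two compounds indistinguishable, which means the larger group is tolerated on the core of compound 1. No measurement shown here explains this result.

On these data alone, whether the same exchange would be tolerated on compound 2, which carries bromine, remains open. Also open, as far as these compounds go, is what a methyl group on the sulfur, or a longer chain in place of the ring-bearing group, would do at this position.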